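The compounds below may be only part of what the source reports. "The series", "measured", "known", "first", "only" and "open" are said of these compounds alone.

Compound 1 `CCCCN(CC)c1cc(C)nc2c1NC(=O)CN2c1ccc(C(C)C)cc1Br`: 0.7%
Compound 2 `CCCCN(CC)c1cc(C)nc2c1NC(=O)CN2c1ccc(C(C)(C)C)cc1Br`: -3.8%
Compound 3 `CCCCN(CC)c1cc(C)nc2c1NC(=O)CN2c1ccc(Br)cc1Br`: 9.4%

In an assay on HEK-293T cells for displacement of a labelled ligand from corticotropin-releasing factor receptor 2 (Homo sapiens), read by scintillation counting, with a stated time of 2 h, tested at 1 uM (a higher number here means more inhibition at the concentration tested (going by the name of the read-out), a lower number less inhibition), compound 2 stands lowest of the three numbers. The step of a number 4.5 percentage points lower from compound 1 to compound 2 (within the scatter) is within the scatter, so compound 1 and compound 2 cannot be told apart; the step of a number 13.2 percentage points higher from compound 2 to compound 3 (beyond the scatter) is the only one beyond it. Compound 4 `CCCCN(CC)c1cc(C)nc2c1NC(=O)CN2c1ccc(C)cc1Br` differs from compound 2 by methyl in place of tert-butyl on an aromatic carbon. For the measured compounds named here, two measured steps bear on shrinking or exchanging that group: a number 13.2 percentage points higher from compound 2 to compound 3 (beyond the scatter) and a number 8.7 percentage points higher from compound 1 to compound 3 (within the scatter), and both point mildly upward when the tert-butyl or isopropyl group is removed. On that basis a small rise, at most near the edge of the scatter, is expected for compound 4, a number 7.8 percentage points higher from compound 2 to compound 4 (within the scatter). Compound 4 is therefore estimated at 4%, within -8% to 16%.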

Compound 4, a percentage reported as inhibition, at one concentration (the size of the read-out at that concentration, not a potency): 5.5%
Compound 4: middle estimate off by 1.5 percentage points, on the low side, and the stated range covers the measured number.
By their numbers in this assay, from the lowest: compounds 2, 1, 4 and 3 (each within the scatter of the next, the first and the last beyond it).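

In this assay methyl on the aromatic carbon meta to the bromo group cannot be told apart from tert-butyl (a number 9.3 percentage points higher from compound 2 to compound 4 (within the scatter)), isopropyl (a number 4.8 percentage points higher from compound 1 to compound 4 (within the scatter)) or bromo (a number 3.9 percentage points lower from compound 3 to compound 4 (within the scatter)). Compound 4 therefore adds no clear step at this position, and the swap from tert-butyl to methyl brings no gain that can be separated from the scatter. Nothing measured here offers an explanation for these numbers. From the compounds shown here alone, it remains open whether a more different group here, such as an amine or a carboxylic acid, would give clear inhibition.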